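The source may hold more compounds than are shown below. What is called first, only, known or untested is meant among the compounds shown, and "the series" means these compounds.

Of the compounds shown here, two of the shared core have been measured in an assay for binding affinity to Neuronal acetylcholine receptor; alpha4/beta2 (Rattus norvegicus) (a lower number here means a stronger inhibitor, a higher number a weaker inhibitor), so far. Compound 1 `Cc1cnc2cc3c(cc2c1)C1CNCC3C1` gives 0.65 nM. Among the measured compounds shown here, compound 2 `c1ccc(-c2cnc3cc4c(cc3c2)C2CNCC4C2)cc1` gives 132 nM, the highest of the two numbers; the one step between them, a 200-fold higher number from compound 1 to compound 2 (2.31 log units; beyond the scatter), is a phenyl in place of a methyl on an aromatic carbon and lies well beyond the scatter.

Compound 3 `c1cnc2cc3c(cc2c1)C1CNCC3C1` is the next member, not yet measured. It differs from compound 2 in one place: hydrogen in place of phenyl on an aromatic carbon. For the measured compounds named here, the only measured step that bears on this change is a 200-fold higher number from compound 1 to compound 2 (2.31 log units; beyond the scatter), which runs the other way, from methyl to phenyl, and was large. Taking the phenyl away again should give back most of that, so a large step down in this assay is expected for compound 3 rather than a change within the scatter, with the remaining uncertainty being how the hydrogen compares with the methyl of compound 1. On this basis compound 3 is estimated at 1 nM, within 0.3 nM to 4 nM, which corresponds to an expected step of a 130-fold lower number from compound 2 to compound 3 (2.12 log units; beyond the scatter).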

Compound 3, inhibition constant: 1.6 nM
Beside the measured number, compound 3's estimate is 1.6-fold (0.20 log units) below it; the measured number falls inside the stated range.
By their numbers in this assay, from the lowest: compound 1; then compound 3; then compound 2.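

With the phenyl gone, an 83-fold lower number from compound 2 to compound 3 (1.92 log units; beyond the scatter) in this assay recovers nearly all of the earlier loss, so this aromatic carbon needs no substituent for a low number, and the high number of compound 2 goes with the phenyl itself. Compounds 1 and 2 alone could not show whether methyl lowered the number or phenyl raised it, but with hydrogen as the reference both changes can be read: phenyl raises it by a large step, while methyl in place of hydrogen accounts for a much smaller gap, seen in reverse as a 2.5-fold higher number from compound 1 to compound 3 (0.39 log units; beyond the scatter) and still beyond the scatter. No measurement at hand gives a reason for either step.

With only hydrogen, methyl and phenyl shown at this carbon, it remains open where an ethyl or propyl chain, a methoxy group or an amine would fall between the low numbers of compounds 1 and 3 and the high number of compound 2. As far as these compounds go, it is also open whether a substituted phenyl or a pyridine ring in place of phenyl would carry the same large step.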